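Methyl to phenyl on sulfur, carried to a second core

The source may hold more compounds than are shown below. What is called first, only, known or untested is meant among the compounds shown, and "the series" means these compounds.

Measured so far in an ADME assay on microsomes from liver (Rattus norvegicus) for metabolic stability, read by HPLC, using NADPH; a higher number here means that the compound lasts longer, a lower number that the compound disappears faster:
compound 1, `CCN(CC)CCNC(=O)c1ccc(C(CC)(CC)c2ccc(OCSC)c(C)c2)n1CC`: compound 1 gives 0.954 h
compound 2, `CCN(CC)CCNC(=O)c1ccc(C(CC)(CC)c2ccc(OCSc3ccccc3)c(C)c2)n1CC`: compound 2 gives 0.895 h
compound 3, `CCN(CC)CCNC(=O)c1cc(C(CC)(CC)c2ccc(OCSC)c(C)c2)cn1CC`: compound 3 gives 0.802 h

Compound 2 differs from compound 1 in one place: phenyl in place of methyl on a sulfur. The step in this assay is a 1.1-fold lower number from compound 1 to compound 2 (0.03 log units; within the scatter), so the two half-lives are not told apart by this measurement.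

Compound 3 has the same atoms as compound 1 joined differently; the difference between the two cores is not broken down here. The values of compound 1 and compound 3 lie within the scatter of each other, as do those of compound 2 and compound 3, so no order among the three measured compounds can be read from these numbers.

Compound 4, `CCN(CC)CCNC(=O)c1cc(C(CC)(CC)c2ccc(OCSc3ccccc3)c(C)c2)cn1CC`, stands to compound 3 as compound 2 stands to compound 1: phenyl in place of methyl on a sulfur. The description of the place is the same word for word in both pairs, so this is the same change, made once on each core.

The step from compound 3 to compound 4 in this assay is expected to be a 1.1-fold lower number from compound 3 to compound 4 (0.03 log units; within the scatter), because a 1.1-fold lower number from compound 1 to compound 2 (0.03 log units; within the scatter) stayed within the scatter and nothing measured here suggests the second core should answer differently. Compound 4 is therefore estimated at 0.75 h, with the expected range running from 0.45 h to 1.3 h.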

Compound 4, half-life: 1.19 h
Compound 4: middle estimate off by 1.6-fold (0.20 log units), on the low side, within the range that was stated.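

In this assay, phenyl in place of methyl on a sulfur gives a 1.5-fold higher number from compound 3 to compound 4 (0.17 log units; within the scatter) on the second core, and set beside the same change on the core of compound 1, the two steps read: the same change on two cores in this assay, a 1.1-fold lower number (0.03 log units; within the scatter) from compound 1 to compound 2 and a 1.5-fold higher number (0.17 log units; within the scatter) from compound 3 to compound 4, 1.6-fold (0.20 log units) apart, within the scatter of two such steps.
On these two cores, then, the change carries over with no difference that these half-lives can resolve, and neither step stands clear of the scatter, so the opposite directions of the two printed steps are not a reversal between cores. For the compounds shown here, this does not show that the change is without effect in general or that the steps are identical, only that neither pair reveals a step beyond the scatter, and two pairs say nothing about how the change would behave on a third core.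

Still open, going by these compounds, is whether a longer chain such as butyl on the sulfur, or an amine or a carboxylic acid carried on the phenyl, would move the half-life beyond the scatter on either core. Also open, on these data alone, is whether a change at any other part of these molecules would depend on the core in a way that this pair of steps cannot reveal.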